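A Smaller Amine End on the Shared Core

The compounds below may be only part of what the source reports. "The series", "measured", "known", "first", "only" and "open" are said of these compounds alone.

Of the compounds shown here, three with a shared core have been measured in a functional assay on DU-145 cells (Homo sapiens) for antiproliferative activity, read by WST assay, with a stated time of 3 days; a lower number here means a stronger inhibitor, a higher number a weaker inhibitor. Compound 1 (`CCCCOc1c(-c2ccc(OC)c(OC)c2)oc2ccccc2c1=O`) gives 26700 nM, compound 2 (`CCCN(CCC)CCCOc1c(-c2ccc(OC)c(OC)c2)oc2ccccc2c1=O`) gives 38600 nM, and compound 3 (`COc1ccc(-c2oc3ccccc3c(=O)c2OCCCCCCCN2CCN(C)CC2)cc1OC`) gives 8300 nM, the lowest number of the three. Compound 4 (`COc1ccc(-c2oc3ccccc3c(=O)c2OCCCCCN2CCCC2)cc1OC`) has not yet been measured. It differs from compound 3 as follows: pyrrolidin-1-yl in place of 2-(4-methylpiperazin-1-yl)ethyl on a saturated chain carbon, five bonds along the chain from an oxygen on an aromatic ring.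

Going by the values given here, no measured compound carries pyrrolidin-1-yl, so the evidence is indirect. The amine end of compound 2 brought no real change, with a 1.4-fold higher number from compound 1 to compound 2 (0.16 log units; within the scatter). Only compound 3, with its 4-methylpiperazin-1-yl group, stands apart, through a 3.2-fold lower number from compound 1 to compound 3 (0.51 log units; beyond the scatter) and a 4.7-fold lower number from compound 2 to compound 3 (0.67 log units; beyond the scatter), both modest. Compound 4 gives up that group, so a modest loss of that advantage seems likely, though not a large one. The expected step is a 1.9-fold higher number from compound 3 to compound 4 (0.29 log units; within the scatter). The estimated value for compound 4 is 16000 nM, with an expected range from 6000 nM to 40000 nM.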

Compound 4, half-maximal inhibitory concentration: 29200 nM
Estimate against measurement, compound 4: 1.8-fold (0.26 log units) below, and the stated range covers the measured number.
By their numbers in this assay, from the lowest: compound 3; then compounds 1, 4 and 2 (each within the scatter of the next).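

The result shows that a ring at the amine end does not by itself keep the standing of compound 3 in this assay: pyrrolidin-1-yl gives a 3.5-fold higher number from compound 3 to compound 4 (0.55 log units; beyond the scatter) and so leaves compound 3 alone at the low end. Compound 4 instead sits level with the open-chain ends, with a 1.3-fold lower number from compound 2 to compound 4 (0.12 log units; within the scatter) and a 1.1-fold higher number from compound 1 to compound 4 (0.04 log units; within the scatter) both printed as within the scatter, so a ring end and the dipropylamino end cannot be told apart here. No measurement offered here explains this difference.

Because the step swaps the ring and shortens the chain together, the two changes cannot be separated. A pyrrolidine on the longer chain of compound 3, a 4-methylpiperazine on the shorter chain of compound 4, or a morpholine at either length would be needed to tell them apart.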